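Five-membered heteroaryl in place of dichlorophenyl: expected recovery

The source may report more compounds than this note shows. Statements on the series, on what has been measured and on what is new or still open speak of the compounds shown alone.

Compound 1 `Cc1ccc(-c2nc(CNc3ccc(C(=O)NO)cc3)n(-c3ccccc3)n2)cc1` gives 62.2% in an assay on Sf9 cells for inhibition of protein deacetylase HDAC6 (Homo sapiens), read by fluorescence, with a stated time of 40 min, tested at 100 nM; a higher number here means more inhibition at the concentration tested (going by the name of the read-out), a lower number less inhibition. Compound 2 `O=C(NO)c1ccc(NCc2nc(-c3ccc(Br)o3)nn2-c2ccccc2)cc1` gives 55.8% in this assay. Compound 3 `O=C(NO)c1ccc(NCc2nc(-c3ccc(Cl)c(Cl)c3)nn2-c2ccccc2)cc1` gives 34.5% in this assay and stands lowest of the three measured numbers, with compound 2 nearest and compound 1 furthest, both gaps beyond the scatter. Compound 4 `Cc1ccc(-c2nc(CNc3ccc(C(=O)NO)cc3)n(-c3ccccc3)n2)s1` differs from compound 3 by 5-methylthiophen-2-yl in place of 3,4-dichlorophenyl on an aromatic carbon. Among the measured compounds shown here, the steps that bear on this are a number 27.7 percentage points lower from compound 1 to compound 3 (beyond the scatter) and a number 21.3 percentage points lower from compound 2 to compound 3 (beyond the scatter), both introducing 3,4-dichlorophenyl; the present change runs the other way. The step of a number 6.4 percentage points lower from compound 1 to compound 2 (within the scatter), six-membered to five-membered ring, stayed within the scatter. A modest rise is therefore expected, a number 22.5 percentage points higher from compound 3 to compound 4 (beyond the scatter). For compound 4 the estimate is 57%, within 42% to 70%.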

Compound 4, a percentage reported as inhibition, at one concentration (the size of the read-out at that concentration, not a potency): 79.7%
The estimate for compound 4 lay 22.7 percentage points below the measured number; measured number outside the range, above it.
By their numbers in this assay, from the lowest: compound 3; then compounds 2 and 1 (each within the scatter of the next); then compound 4.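

At this position, 5-methylthiophen-2-yl does more than undo the loss seen with 3,4-dichlorophenyl: the step is a number 45.2 percentage points higher from compound 3 to compound 4 (beyond the scatter), and it also exceeds the other two groups, with a number 23.9 percentage points higher from compound 2 to compound 4 (beyond the scatter) and a number 17.5 percentage points higher from compound 1 to compound 4 (beyond the scatter). A five-membered aromatic ring with 1 hetero atom does not by itself give the high number in this assay, as compound 2 also carries one. Nothing available accounts for the size of these steps.

From the compounds shown here alone, it remains open whether the sulfur or the methyl carries the rise, which 5-methylfuran-2-yl would separate. Going by these compounds, whether an ethyl group or an amine can replace that methyl also remains open.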